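The source may report more compounds than this note shows. Statements on the series, on what has been measured and on what is new or still open speak of the compounds shown alone.

Measured in an ADME assay on CHO-K1 cells (Cricetulus griseus) for cytotoxicity, read by MTT assay, with a stated time of 24 h; a higher number here means that more compound is tolerated, a lower number that less compound is tolerated:
- compound 1 `Oc1ccccc1NC(=S)Nc1ccc2[nH]ccc2c1`: 509000 nM
- compound 2 `Oc1cccc(NC(=S)Nc2ccc3[nH]ccc3c2)c1`: 977000 nM
- compound 3 `OCc1ccc(NC(=S)Nc2ccc3[nH]ccc3c2)cc1`: 1080000 nM

Compound 3 lies within the scatter of compound 2 and beyond the scatter of compound 1, on the better-tolerated side. The next compound is compound 4 `S=C(Nc1ccc(Oc2ccccc2)cc1)Nc1ccc2[nH]ccc2c1`, with phenoxy in place of hydroxymethyl on an aromatic carbon, para to a large group: phenoxy in place of hydroxymethyl on an aromatic carbon. Within the data shown here, no measured pair shows a change of this kind, so the expectation is a judgement and the range stays wide. In this assay a step to a lower number, beyond the scatter, is expected. The expected size is a 3.6-fold lower number from compound 3 to compound 4 (0.56 log units; beyond the scatter). For compound 4 the estimate is 300000 nM, with an expected range of 80000 nM to 1000000 nM.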

Compound 4, concentration lethal to 50% of the cells: 36000 nM
Compound 4: the middle estimate sits 8.3-fold (0.92 log units) above what was measured, outside the stated range (below it).
By their numbers in this assay, from the lowest: compound 4; then compounds 1, 2 and 3 (each within the scatter of the next, the first and the last beyond it).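

In this assay, among these compounds, the change from hydroxymethyl to phenoxy, on an aromatic carbon para to a large group, is the first single-place change, and it is large (a 30-fold lower number from compound 3 to compound 4 (1.48 log units; beyond the scatter)). This position is therefore not indifferent to what it carries. No measurement given here bears on the reason for this step.

Going by these compounds, it remains open whether the added aromatic ring or the lost hydroxymethyl accounts for the step. A methoxy, benzyl, amine or carboxylic acid group at this place could separate the two.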